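A few compounds are considered here, and "the series" means these few. Any claim that something is new, unique, unknown or untested is made for them only; others in the source may bear on it.

Compound 1 `Cc1ccc2c(O)cc(=O)[nH]c2c1`: in a functional assay on HL-60 cells (Homo sapiens), read by MTT assay, with a stated time of 72 h (on this read-out lower numbers stand for stronger inhibition of growth and higher numbers for weaker inhibition of growth), compound 1 reaches only the limit > 10000000 nM.
Compound 2 `O=c1cc(O)c2cccc(C(F)(F)F)c2[nH]1`: in this assay compound 2 likewise reaches only the limit > 10000000 nM.

Compound 2 thus stands at the limit of this assay rather than at a measured number, and the limit of > 10000000 nM in this assay, at which 2 of the 2 values shown sit, shows that both values sit at that same limit. Compound 3 `O=c1cc(O)c2cccc(F)c2[nH]1` differs from compound 2 by fluoro in place of trifluoromethyl on an aromatic carbon. Among the measured compounds shown here, no measured step between these two compounds exists, so the expected change in this assay is none beyond the scatter. Compound 3 is therefore expected to remain at or near the limit, estimated at 10000000 nM with a range from 1000000 nM to 30000000 nM. The step is expected to be a number no higher from compound 2 to compound 3 (the limit leaves the size open).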

Compound 3, concentration for 50% growth inhibition: > 10000000 nM
Compound 3: a limit, no number (the forecaster's own chance of this, stated with the estimate: 85%); the middle value lies on the limit itself.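

No step can be read from compound 2 to compound 3, as both results are limits and not numbers: the limit of > 10000000 nM in this assay, at which 3 of the 3 values shown sit. In this assay the compounds shown leave open how strongly, if at all, any of them inhibits growth.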